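This account rests on a few compounds, and the source may have more. Where it says the series, first, only, none or still open, it means among the compounds named here.

In an ADME assay on L02 cells (Homo sapiens) for cytotoxicity, read by MTT assay, with a stated time of 24 h (a lower number here means a stronger inhibitor, a higher number a weaker inhibitor), compound 1 `COc1ccc(/C=C2\CN(C)C/C(=C\c3ccccc3F)C2=O)cc1` gives 22100 nM and compound 2 `COc1cc(/C=C2\CN(C)C/C(=C\c3ccc(F)cc3)C2=O)cc(OC)c1` gives 21900 nM so the two stand level, within the scatter. Compound 3 `COc1cc(/C=C2\CN(C)C/C(=C\c3ccc(Cl)cc3Cl)C2=O)cc(OC)c1` carries 2,4-dichlorophenyl in place of 4-fluorophenyl on a double-bonded chain carbon bound to a double-bonded ring carbon. Among the compounds with values here, no measured step between closely matched compounds is available as a guide. In this assay only a small move toward a lower number is expected, with the estimated 1.5-fold lower number from compound 2 to compound 3 (0.16 log units; within the scatter) staying within the scatter. Compound 3 is expected at 15000 nM (estimated range 6000 nM to 35000 nM).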

Compound 3, half-maximal inhibitory concentration: 18800 nM
For compound 3 the middle estimate is 1.3-fold (0.10 log units) below the measured one; low and high end bracket the measured number.
By their numbers in this assay, from the lowest: compounds 3, 2 and 1 (each within the scatter of the next).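

At the place on a double-bonded chain carbon bound to a double-bonded ring carbon, 2,4-dichlorophenyl in place of 4-fluorophenyl gives a 1.2-fold lower number from compound 2 to compound 3 (0.07 log units; within the scatter) in this assay. This is the only step shown between compounds that differ in one place, and it shows that this exchange of halogen-bearing phenyl groups leaves the two compounds level. No measurement shown gives a reason for this result. Still open, from the compounds shown here alone, is whether a group of another kind, such as an amine or a carboxylic acid, would give a step beyond the scatter in this place. Also open, going by these compounds, is whether 2,4-dichlorophenyl would give the same result with the methoxy groups of compound 3 exchanged.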